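This account rests on a few compounds, and the source may have more. Where it says the series, first, only, none or still open, it means among the compounds named here.

Going by the values given here, in a functional assay on A549 cells (Homo sapiens) for cytotoxicity, read by MTT assay, with a stated time of 48 h (a higher number here means a weaker inhibitor, a lower number a stronger inhibitor), compound 3 (`C=C1CCC[C@]2(C)CCC(c3cn(-c4cccc(OC)c4)nn3)=CC[C@@]12C`) gives 11200 nM and holds the lowest of the three numbers so far. Higher numbers belong to compound 2 (`C=C1CCC[C@]2(C)CCC(c3cn(-c4ccccc4C(C)=O)nn3)=CC[C@@]12C`) at 37700 nM and to compound 1 (`C=C1CCC[C@]2(C)CCC(c3cn(-c4ccc(I)cc4)nn3)=CC[C@@]12C`) at 137000 nM in the same test. Compound 4 (`C=C1CCC[C@]2(C)CCC(c3cn(-c4ccc(C)cc4)nn3)=CC[C@@]12C`) has not yet been measured. Among the compounds with values here, the one structural change is 4-methylphenyl in place of 3-methoxyphenyl on an aromatic nitrogen and the shared core stays as it is.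

Within the data shown here, no measured step makes this exact swap, so the guide is indirect. Two measured steps arrive at 3-methoxyphenyl and both lower the number: a 12-fold lower number from compound 1 to compound 3 (1.09 log units; beyond the scatter) is large and a 3.4-fold lower number from compound 2 to compound 3 (0.53 log units; beyond the scatter) is modest. A third step, a 3.6-fold lower number from compound 1 to compound 2 (0.56 log units; beyond the scatter) is also modest and shows that leaving 4-iodophenyl lowered the number in both cases. Among the measured groups, only 4-iodophenyl in compound 1 at 137000 nM shares its position number with 4-methylphenyl, though three compounds cannot separate position from group. Leaving 3-methoxyphenyl is therefore expected to raise the number, by a modest step and not by the full large one. In this assay the expected change is a 3.1-fold higher number from compound 3 to compound 4 (0.49 log units; beyond the scatter) as an estimate. For compound 4 the estimated value is 35000 nM with an expected range from 11000 nM to 110000 nM as the likely span.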

Compound 4, half-maximal inhibitory concentration: 58800 nM
Beside the measured number, compound 4's estimate is 1.7-fold (0.23 log units) below it, and the stated range covers the measured number.
By their numbers in this assay, from the lowest: compound 3; then compounds 2 and 4 (each within the scatter of the next); then compound 1.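

In this assay, 4-methylphenyl in place of 3-methoxyphenyl gives a 5.3-fold higher number from compound 3 to compound 4 (0.72 log units; beyond the scatter) and leaves compound 3 with the lowest of the four numbers, so a plain methyl-bearing phenyl does not match it. Methyl in place of iodo gives a 2.3-fold lower number from compound 1 to compound 4 (0.37 log units; beyond the scatter), the first comparison in which the substituent changes while its ring position stays the same, and it shows that the group at that position alone can move the number. With a 1.6-fold higher number from compound 2 to compound 4 (0.19 log units; within the scatter), 4-methylphenyl and 2-acetylphenyl cannot be told apart here, and no outside measurement is available to explain any of these steps.

Going by these compounds alone, the four compounds leave open whether the lower number of compound 3 goes with the methoxy group itself or with where it sits: methoxy appears at only one ring position and methyl at only one, and 4-methoxyphenyl or 3-methylphenyl would separate the two. Also open, from the compounds shown here alone, is where a phenyl ring carrying an amine or a carboxylic acid would fall in this order.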